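The source may report more compounds than this note shows. Statements on the series, on what has been measured and on what is new or still open speak of the compounds shown alone.

Measured so far in a functional assay on KB 3-1 cells (Homo sapiens) for antiproliferative activity, read by MTT assay; on this read-out lower numbers stand for stronger inhibition and higher numbers for weaker inhibition

- compound 1 `C[C@@H]1[C@H]2CC(=O)[C@H](C)[C@H]2C[C@H]1O[Si](c1ccccc1)(c1ccccc1)C(C)(C)C` gives 15200 nM
- compound 2 `C=CCC[C@H]1CC(=O)[C@@H]2C=CC(=O)[C@H]12` gives 16300 nM
- compound 3 `C[C@@H]1[C@@H]2[C@@H](CC(=O)[C@H]2C)C[C@H]1O[Si](c1ccccc1)(c1ccccc1)C(C)(C)C` gives 7400 nM

Compound 3 has the lowest number of the three, and its gaps to compound 1 and to compound 2 both lie just beyond the scatter. All three compounds therefore sit close together, and none shows strong inhibition in this assay on these numbers.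

The next compound to be read is compound 4 `C=CC[C@@H]1C(=O)C[C@H]2C[C@@H](O[Si](c3ccccc3)(c3ccccc3)C(C)(C)C)[C@H](C)[C@H]21`. Relative to compound 3 the change is vinyl in place of hydrogen on a saturated chain carbon bound to a saturated ring carbon. The same difference, cut one bond further out, reads methyl to allyl.

Going by the values given here, no two measured compounds differ in one place, so no measured step bears directly on this change. The expectation rests only on the narrow spread of the series, with compound 3 at 7400 nM and compound 2 at 16300 nM in the same assay. No step beyond the scatter is expected, in either direction. The estimated step of a 1.4-fold higher number from compound 3 to compound 4 (0.13 log units; within the scatter) stays within the scatter. For compound 4 the expected value is 10000 nM, with an estimated range from 4500 nM to 22000 nM as its upper end.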

Compound 4, half-maximal inhibitory concentration: 16200 nM
Compound 4: the middle estimate sits 1.6-fold (0.21 log units) below what was measured, within the range that was stated.
By their numbers in this assay, from the lowest: compound 3; then compounds 1, 4 and 2 (each within the scatter of the next).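

In this assay, going by these compounds alone, vinyl in place of hydrogen on a saturated chain carbon bound to a saturated ring carbon gives a 2.2-fold higher number from compound 3 to compound 4 (0.34 log units; beyond the scatter), the first single-place step and a modest one that lies beyond the scatter. Read one bond further out as methyl to allyl, the change moves the number in the direction of weaker inhibition, so at this position the added vinyl brings no gain over hydrogen, while the loss stays modest and the compound still gives a measurable half-maximal value. No available measurement accounts for this step, so it stands as an observation without an explanation.

This single step cannot show whether the rise is particular to vinyl or would follow from other groups at the same carbon, so no trend can yet be assigned to the position. Going by these compounds, how an amine, a carboxylic acid or a longer chain in that place would read in this assay stays open, as does whether the same change would give a similar step on a different core.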